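Piperidinyl Carbonyl in Place of Thiazolyl Carbonyl

The compounds below may be only part of what the source reports. "The series", "measured", "known", "first", "only" and "open" are said of these compounds alone.

Compound 3 `Cc1nc(C(=O)N2CCc3nc(C#Cc4ccccc4)sc3C2)cs1` is one of three compounds examined in an assay on HEK293 cells for negative allosteric modulation of metabotropic glutamate receptor 5 (Homo sapiens), read by FLIPR, with a stated time of 1 h; on this read-out higher numbers stand for weaker inhibition and lower numbers for stronger inhibition. In this assay compound 3 gives > 10000 nM, which is a limit of the assay and not a number. Compound 2 `O=C(C1CCOCC1)N1CCc2nc(C#Cc3ccccc3)sc2C1` stands in the same place: in this assay compound 2 gives > 10000 nM, again a limit. Compound 1 `CC(C)CN1CCc2nc(C#Cc3ccccc3)sc2C1` carries isobutyl on the amine nitrogen in the ring, and in this assay compound 1 gives 650 nM. The two steps away from the isobutyl compound were an at least 15-fold higher number from compound 1 to compound 2 (1.18 log units; beyond the scatter) and an at least 15-fold higher number from compound 1 to compound 3 (1.18 log units; beyond the scatter), both large, and the carbonyl compounds rest at the limit of > 10000 nM in this assay, at which 2 of the 3 values shown sit. The step between the two carbonyl compounds, a step that the two limits leave unreadable from compound 2 to compound 3, cannot be read from two limits.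

Compound 4 `O=C(N1CCCCC1)N1CCc2nc(C#Cc3ccccc3)sc2C1` differs from compound 3 in one place: piperidin-1-yl in place of 2-methyl-1,3-thiazol-4-yl on a carbonyl carbon. Among the compounds with values here, no measured step covers an exchange of this kind directly; the only comparison between two carbonyl groups is the unreadable one. Within the data shown here, both carbonyl compounds so far sit at the limit, and compound 4 keeps a carbonyl on the amine nitrogen in a ring, so a number at or near that limit is expected. The expected step that the limit leaves unreadable from compound 3 to compound 4 is therefore none that could be read beyond the scatter. For compound 4 the estimate is 20000 nM, with a range from 5000 nM to 80000 nM.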

Compound 4, half-maximal inhibitory concentration: > 10000 nM
Compound 4 was reported as a limit; the forecaster's own chance of this, stated with the estimate: 75%; the middle value does not contradict the limit.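

With (piperidin-1-yl)carbonyl on the amine nitrogen in a ring, this assay records an at least 15-fold higher number from compound 1 to compound 4 (1.18 log units; beyond the scatter), so a third carbonyl group now stands apart from isobutyl in the same way as the first two. The loss therefore does not hang on one kind of group on the carbonyl carbon: piperidin-1-yl, a six-membered non-aromatic ring with 1 hetero atom, ends at the same limit as 2-methyl-1,3-thiazol-4-yl, a five-membered aromatic ring with 2 hetero atoms, and as oxan-4-yl, and the steps among compound 2, compound 3 and compound 4 cannot be read, as all three values are limits. In this small set, every carbonyl compound sits at the limit and only compound 1 gives a number: the limit of > 10000 nM in this assay, at which 3 of the 4 values shown sit.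

Going by these compounds, how far the three carbonyl compounds lie past that limit stays open, so no order among them can be given. Also open, on these data alone, is whether the isobutyl result depends on that chain in particular, or whether a longer alkyl chain, a benzyl group or a cyclopropylmethyl group on the same nitrogen would also give a number within the range of the assay.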